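The compounds below may be only part of what the source reports. "The series", "measured", "known", "first", "only" and "open" are said of these compounds alone.

Measured compounds:
compound 1 `COc1cccc(Oc2ccc3c(NCCCNCc4cccc(OC)c4O)ccnc3c2)c1` — 317 10^-6 cm/s
compound 2 `COc1cccc(CNCCCNc2ccnc3cc(Oc4ccc(C(C)(C)C)cc4)ccc23)c1O` — 317 10^-6 cm/s

In an ADME assay for permeability, using PAMPA, with a stated time of 30 min, at pH 7.4 (on this read-out higher numbers stand for higher permeability and lower numbers for lower permeability), compound 2 gives 317 10^-6 cm/s, level with compound 1 at the digits shown. Within the data shown here, the one measured step, no change at the digits printed from compound 1 to compound 2 (within the scatter), changes the aryl group on the ether oxygen and leaves the read-out unchanged within the scatter, so on the present numbers this position tolerates that exchange without a shift.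

Compound 3 `COc1cccc(CNCCCNc2ccnc3cc(Cc4cccc(C(F)(F)F)c4)ccc23)c1O` differs from compound 2 as follows: 3-(trifluoromethyl)benzyl in place of 4-(tert-butyl)phenoxy on an aromatic carbon. Among the measured compounds shown here, no measured step covers an exchange of this kind, in which the ether oxygen is removed and a trifluoromethyl-bearing benzyl group enters; the only step known bears on the aryl part of the ether alone and was flat. With nothing in the data pointing to a shift, the expected step is a 1.1-fold lower number from compound 2 to compound 3 (0.02 log units; within the scatter). For compound 3 the expected value in this assay is 300 10^-6 cm/s. The range expected for compound 3 runs from 150 10^-6 cm/s to 550 10^-6 cm/s.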

Compound 3, apparent permeability: 23 10^-6 cm/s
Estimate against measurement, compound 3: 13-fold (1.12 log units) above; measured number outside the range, below it.
By their numbers in this assay, from the lowest: compound 3; then compounds 1 and 2 (each within the scatter of the next).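

In this assay, the exchange at this aromatic carbon that replaces the whole aryl ether has a large effect: 3-(trifluoromethyl)benzyl in place of 4-(tert-butyl)phenoxy gives a 14-fold lower number from compound 2 to compound 3 (1.14 log units; beyond the scatter) and in place of 3-methoxyphenoxy gives a 14-fold lower number from compound 1 to compound 3 (1.14 log units; beyond the scatter) on the same core. The position therefore tolerates a change of aryl group on the ether oxygen, yet the read-out does not stay flat for every substituent here, even though the leaving and entering groups have the same heavy-atom count. No available measurement offers an explanation for the large step.

Going by these compounds, two features change together in compound 3, the ether oxygen and the aryl substitution, so the share of each remains open. A 3-(trifluoromethyl)phenoxy group or a 4-(tert-butyl)benzyl group on the shared core would separate the two.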